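Para substituent swap on the aryl oxadiazole: methyl to bromo

The compounds below may be only part of what the source reports. "The series", "measured", "known", "first", "only" and "open" are said of these compounds alone.

In an ADME assay on HepG2 cells (Homo sapiens) for cytotoxicity, read by MTT assay, with a stated time of 48 h (a higher number here means that more compound is tolerated, a lower number that less compound is tolerated), compound 3 `CC(=O)OC[C@H]1O[C@H](OC[C@@H](Cn2cc(CN(c3nc(-c4ccc(C)cc4)no3)C3CCCCC3)nn2)OC(C)=O)C=C[C@@H]1OC(C)=O` gives 36.8 ug/mL, the lower of the two numbers shown. Compound 2 `CC(=O)OC[C@H]1O[C@H](OC[C@@H](Cn2cc(CN(c3nc(-c4ccc(Cl)cc4)no3)C3CCCCC3)nn2)OC(C)=O)C=C[C@@H]1OC(C)=O` gives 46.9 ug/mL, which lies within the scatter of compound 3. Compound 1 `CC(=O)OC[C@H]1O[C@H](OC[C@@H](Cn2cc(CN(c3nc(-c4cccc([N+](=O)[O-])c4)no3)C3CCCCC3)nn2)OC(C)=O)C=C[C@@H]1OC(C)=O` gives > 200 ug/mL, a limit of this assay rather than a number.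

Compound 4 `CC(=O)OC[C@H]1O[C@H](OC[C@@H](Cn2cc(CN(c3nc(-c4ccc(Br)cc4)no3)C3CCCCC3)nn2)OC(C)=O)C=C[C@@H]1OC(C)=O` differs from compound 3 by bromo in place of methyl on an aromatic carbon. Among the compounds with values here, the one measured step at this position is a 1.3-fold lower number from compound 2 to compound 3 (0.11 log units; within the scatter). The steps of an at least 4.2-fold lower number from compound 1 to compound 2 (0.62 log units; beyond the scatter) and an at least 5.4-fold lower number from compound 1 to compound 3 (0.73 log units; beyond the scatter) start from the limit of compound 1 and only bound the change from the 3-nitrophenyl. In this assay the step is therefore expected to be a 1.1-fold higher number from compound 3 to compound 4 (0.04 log units; within the scatter), with no shift beyond the scatter. Compound 4 is expected to give 40 ug/mL, estimated between 18 ug/mL and 90 ug/mL.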

Compound 4, half-maximal cytotoxic concentration: 47.6 ug/mL
Estimate against measurement, compound 4: 1.2-fold (0.08 log units) below; the measured number falls inside the stated range.
By their numbers in this assay, from the lowest: compounds 3, 2 and 4 (each within the scatter of the next). At a limit, above all of these: compound 1.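

In this assay, bromo in place of methyl gives a 1.3-fold higher number from compound 3 to compound 4 (0.11 log units; within the scatter), and bromo in place of chloro gives a 1.0-fold higher number from compound 2 to compound 4 (0.01 log units; within the scatter), so this read-out does not separate methyl, chloro and bromo on this aromatic carbon. The 4-bromophenyl also gives an at least 4.2-fold lower number from compound 1 to compound 4 (0.62 log units; beyond the scatter), a step that only bounds the change from the 3-nitrophenyl. The value of compound 1 is a limit: the limit of > 200 ug/mL in this assay, at which 1 of the 4 values shown sits.

Still open, as far as these compounds go, is whether the gap to compound 1 follows the nitro group itself or the place it occupies on the ring. Also open, from the compounds shown here alone, is how an amine or a carboxylic acid on this aromatic carbon would read in this assay.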